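Amide Swap: From Cyclohexyl to 3,4-Difluorophenyl

This account rests on a few compounds, and the source may have more. Where it says the series, first, only, none or still open, it means among the compounds named here.

Measured compounds:
Compound 1, `O=C(C1CCC1)N1CCCC[C@@H]1c1nc(-c2cccc(F)c2)no1`: 600 nM; 650 nM (2 entries)
Compound 2, `O=C(C1CCCCC1)N1CCCC[C@@H]1c1nc(-c2cccc(F)c2)no1`: 3500 nM

In an in vitro functional assay on HEK293-A cells for positive allosteric modulation of metabotropic glutamate receptor 5 (Homo sapiens), read by fluorescence and calcium flux, with a stated time of 140 s (on this read-out lower numbers stand for an effect already at smaller amounts and higher numbers for an effect only at larger amounts of compound), compound 1 gives 600 nM; 650 nM (2 entries), and the closeness of these repeats, (the several entries of compound 1 in this assay, 600 nM; 650 nM (2 entries)), shows how little such readings wander. Going by the values given here, compound 2 gives 3500 nM in this assay; this is the only complete number for it, and one further entry yields no single value. Compound 2 and compound 1 share a core and differ only in the ring on the carbonyl, and the two values lie well apart.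

Compound 3, `O=C(c1ccc(F)c(F)c1)N1CCCC[C@@H]1c1nc(-c2cccc(F)c2)no1`, has not yet been tested. It carries 3,4-difluorophenyl in place of cyclohexyl on a carbonyl carbon. Among the compounds with values here, no measured pair shows what this change does. An aromatic ring here is expected to help rather than hurt, so compound 3 is estimated to be more potent than compound 2, with the step of a 4.4-fold lower number from compound 2 to compound 3 (0.64 log units; beyond the scatter). Compound 3 is expected at 800 nM, within 250 nM to 2500 nM.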

Compound 3, half-maximal effective concentration: 1400 nM
Beside the measured number, compound 3's estimate is 1.8-fold (0.24 log units) below it, and the stated range covers the measured number.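

In this assay, the place on the carbonyl carbon accepts an aromatic ring, and replacing cyclohexyl with 3,4-difluorophenyl gives a 2.5-fold lower number from compound 2 to compound 3 (0.40 log units; beyond the scatter). This swap changes the ring from non-aromatic to aromatic and adds two fluorine atoms at once, so this single step cannot be credited to either change alone. The step is modest, but it is supported by how closely repeat readings agree: the several entries of compound 1 in this assay, 600 nM; 650 nM (2 entries).

The compounds shown leave open whether a plain phenyl ring or a phenyl ring with a single fluorine would give a similar number, so the share of each fluorine remains unknown. From the compounds shown here alone, it is also open how this position would respond to a ring carrying an amine or a carboxylic acid.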